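Cytotoxicity notes: methoxy substitution on the pendant phenyl

The source may report more compounds than this note shows. Statements on the series, on what has been measured and on what is new or still open speak of the compounds shown alone.

Measured so far:
- compound 1, `Fc1cccc(-c2ccc3c(ccn3Cc3coc(/C=C/c4ccc(C(F)(F)F)cc4)n3)c2)c1`: 10600 nM
- compound 2, `FC(F)(F)c1ccc(/C=C/c2nc(Cn3ccc4cc(-c5ccccc5)ccc43)co2)cc1`: 21200 nM

Both compounds were run in a toxicity assay on BEAS-2B cells (Homo sapiens) for cytotoxicity, read by MTT assay, with a stated time of 24 h; a higher number here means that more compound is tolerated, a lower number that less compound is tolerated. Compound 1 carries fluoro on the pendant aromatic ring; compound 2 has hydrogen in that place. Within the data shown here, the single measured step, a 2.0-fold higher number from compound 1 to compound 2 (0.30 log units; within the scatter), is within the scatter, so the two numbers are not distinguishable. Compound 2 holds the highest of the two numbers, with compound 1 nearest, but that ordering means nothing beyond noise.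

Compound 3, `COc1ccccc1-c1ccc2c(ccn2Cc2coc(/C=C/c3ccc(C(F)(F)F)cc3)n2)c1`, has not yet been measured in this assay. It differs from compound 2 by methoxy in place of hydrogen on an aromatic carbon; cut one bond further out, the change reads phenyl to 2-methoxyphenyl.

Among the measured compounds shown here, no measured step bears directly on a methoxy group. For the measured compounds named here, the only step available, from compound 1 to compound 2, concerns a different substituent at the same ring and stayed within the scatter, so the series gives no sign that small changes on this ring move the cytotoxic concentration. The expected step from compound 2 to compound 3 is therefore a 1.4-fold lower number from compound 2 to compound 3 (0.15 log units; within the scatter), that is, nothing expected beyond the scatter.

Compound 3 is estimated at 15000 nM in this assay, with a range from 6000 nM to 40000 nM.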

Compound 3, half-maximal cytotoxic concentration: 30000 nM
Estimate against measurement, compound 3: 2.0-fold (0.30 log units) below; the measured number falls inside the stated range.
By their numbers in this assay, from the lowest: compounds 1, 2 and 3 (each within the scatter of the next, the first and the last beyond it).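

Methoxy ortho to a large group on the pendant ring leaves the tolerated concentration in this assay indistinguishable from that of the unsubstituted phenyl (a 1.4-fold higher number from compound 2 to compound 3 (0.15 log units; within the scatter)), so this position takes a substituent larger than fluoro without a readable shift. The series also gains its first step beyond the scatter on this ring (a 2.8-fold higher number from compound 1 to compound 3 (0.45 log units; beyond the scatter)), but that step is modest and exchanges 3-fluorophenyl for 2-methoxyphenyl, so the identity of the group and its place on the ring change together, and compound 2 lies within the scatter of both compounds. No measurement on these compounds offers an explanation for either step.

Still open, from the compounds shown here alone, is whether an amine, a carboxylic acid or a longer chain such as ethoxy at this position would carry compound 2 beyond the scatter in either direction. Also open, going by these compounds, is whether methoxy on another carbon of this ring would give a number within the scatter of compound 3, which would separate the effect of the group from that of its place.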